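The compounds below may be only part of what the source reports. "The series", "measured", "known", "first", "only" and "open" are said of these compounds alone.

Going by the values given here, in a functional assay on HL-60 cells (Homo sapiens) for cytotoxicity, read by XTT assay, with a stated time of 3 days (a higher number here means a weaker inhibitor, a lower number a stronger inhibitor), compound 2 (`OC[C@H]1O[C@@H](n2cc(F)c3c(-c4ccoc4)ncnc32)[C@H](O)[C@@H]1O`) gives 2000 nM and compound 1 (`OC[C@H]1O[C@@H](n2cc(F)c3c(-c4nccs4)ncnc32)[C@H](O)[C@@H]1O`) gives 1000 nM, so compound 2 stands within the scatter of the only other measured number. Compound 3 (`OC[C@H]1O[C@@H](n2cc(F)c3c(-c4ccsc4)ncnc32)[C@H](O)[C@@H]1O`) has thiophen-3-yl in place of furan-3-yl on an aromatic carbon of the shared core: thiophen-3-yl in place of furan-3-yl on an aromatic carbon. Among the compounds with values here, no measured compound yet carries thiophen-3-yl, so this exchange has no direct precedent. Within the data shown here, the nearest evidence is the single measured step at the same place, a 2.0-fold higher number from compound 1 to compound 2 (0.30 log units; within the scatter), where furan-3-yl replaced 1,3-thiazol-2-yl. With that exchange of one five-membered aromatic ring for another staying inside the scatter, no step beyond the scatter is expected in this assay here, and no direction can be favoured. The expected step is a 1.3-fold lower number from compound 2 to compound 3 (0.12 log units; within the scatter). For compound 3 the estimated value is 1500 nM, with an expected range from 500 nM to 4500 nM.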

Compound 3, half-maximal inhibitory concentration: 4900 nM
Compound 3: the middle estimate sits 3.3-fold (0.51 log units) below what was measured; measured number above the stated range.
By their numbers in this assay, from the lowest: compounds 1 and 2 (each within the scatter of the next); then compound 3.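

In this assay the exchange of furan-3-yl for thiophen-3-yl gives a 2.5-fold higher number from compound 2 to compound 3 (0.39 log units; beyond the scatter) and so passes beyond the scatter, although the two groups match in their counts of heavy atoms, donors and acceptors and differ in oxygen against sulfur. Thiophen-3-yl in place of 1,3-thiazol-2-yl gives a 4.9-fold higher number from compound 1 to compound 3 (0.69 log units; beyond the scatter) and leaves compound 3 with the highest number of the three, so this place does respond to the choice of five-membered aromatic ring, which the earlier pair alone did not show. Nothing at hand accounts for these steps.

The three compounds carry only five-membered aromatic rings at this place, so they leave open what an amine, a carboxylic acid or a longer chain would do there. They also leave open whether the same order would hold in other cells.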